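A second trifluoromethyl group on the benzyl ring

The compounds below may be only part of what the source reports. "The series", "measured", "known", "first", "only" and "open" are said of these compounds alone.

Within the data shown here, the two compounds measured so far share one core and differ only in the substituents on the outer benzyl ring. Compound 1 `Cc1cc(C(=O)O)nn1Cc1cc(Br)ccc1OCc1cccc(C(F)(F)F)c1` gives 309 nM in an assay on CHO-K1 cells for displacement of a labelled ligand from prostaglandin E2 receptor EP1 subtype (Homo sapiens); a lower number here means a stronger inhibitor, a higher number a weaker inhibitor. Compound 2 `Cc1cc(C(=O)O)nn1Cc1cc(Br)ccc1OCc1ccc(Cl)c(C(F)(F)F)c1` carries an added chloro group and gives 575 nM in this assay. Compound 1 has the lower of the two numbers, but the step of a 1.9-fold higher number from compound 1 to compound 2 (0.27 log units; within the scatter) lies within the scatter, so the two cannot be ranked.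

The unmeasured compound 3 `Cc1cc(C(=O)O)nn1Cc1cc(Br)ccc1OCc1cc(C(F)(F)F)cc(C(F)(F)F)c1` differs from compound 1 by trifluoromethyl in place of hydrogen on an aromatic carbon. Among the measured compounds shown here, the only measured step that bears on this is the one from compound 1 to compound 2, where a further group on the same ring changed the number by less than the scatter allows one to read. A second trifluoromethyl group is a comparable change, so no step beyond the scatter is expected in this assay, with the direction left open.

For compound 3 a value of 450 nM is expected, with a range from 150 nM to 1400 nM, which means an expected step of a 1.5-fold higher number from compound 1 to compound 3 (0.16 log units; within the scatter).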

Compound 3, half-maximal inhibitory concentration: 5250 nM
For compound 3 the middle estimate is 12-fold (1.07 log units) below the measured one; measured number outside the range, above it.
By their numbers in this assay, from the lowest: compounds 1 and 2 (each within the scatter of the next); then compound 3.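

In this assay, a trifluoromethyl group on this aromatic carbon, meta to a large group and meta to the trifluoromethyl group already present, proves to be a far from neutral change: it gives a 17-fold higher number from compound 1 to compound 3 (1.23 log units; beyond the scatter) and clearly weakens the compound. Among these compounds, the earlier step with chloro, a 1.9-fold higher number from compound 1 to compound 2 (0.27 log units; within the scatter), could not be read as a change at all, so compound 3 is the first case here in which adding a group to this outer ring has a clear effect on the number, and that effect is large. No measurement among these compounds accounts for this loss of strength.

The compounds shown leave open whether the loss belongs to trifluoromethyl itself or would follow any group placed on this carbon, since only one group has been seen there. A single fluorine atom, a methyl group or a nitrile on the same carbon of compound 1 would help to separate these two readings, and an amine or a carboxylic acid there would test a quite different kind of group.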